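Swapping the Butoxy Chain for Bromine on the Benzyl Ring

This account rests on a few compounds, and the source may have more. Where it says the series, first, only, none or still open, it means among the compounds named here.

Compound 1 `CCCCOc1ccccc1Cc1cnc(N)nc1N` stands lowest of the two numbers at hand: in an assay for inhibition of Dihydrofolate reductase (Gallus gallus) (a higher number here means a weaker inhibitor, a lower number a stronger inhibitor), compound 1 gives 8710 nM, while its nearest neighbour compound 2 `C=CCOc1ccccc1Cc1cnc(N)nc1N` gives 21400 nM, a step of a 2.5-fold higher number from compound 1 to compound 2 (0.39 log units; beyond the scatter). Compound 3 `Nc1ncc(Cc2ccccc2Br)c(N)n1` differs from compound 1 in one place: bromo in place of butoxy on an aromatic carbon. Within the data shown here, the only step measured so far alters the chain on that oxygen, not its removal, so it bears on this change only loosely; removing the chain altogether is expected to weaken binding somewhat, by about a 1.7-fold higher number from compound 1 to compound 3 (0.24 log units; within the scatter). For compound 3 the estimate in this assay is 15000 nM, ranging from 4000 nM to 60000 nM.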

Compound 3, inhibition constant: 12300 nM
Beside the measured number, compound 3's estimate is 1.2-fold (0.09 log units) above it; measured number inside the range.
By their numbers in this assay, from the lowest: compounds 1, 3 and 2 (each within the scatter of the next, the first and the last beyond it).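

In this assay the single bromo atom stands close to both oxygen-linked chains: bromo for butoxy gives a 1.4-fold higher number from compound 1 to compound 3 (0.15 log units; within the scatter) and bromo for allyloxy gives a 1.7-fold lower number from compound 2 to compound 3 (0.24 log units; within the scatter) while the two chains lie beyond the scatter of each other. An oxygen-linked chain on this aromatic carbon is therefore not needed to keep the number in this range. No measured evidence here explains this result. From the compounds shown here alone, whether an amine, a carboxylic acid or a plain hydrogen on this carbon would shift the number remains open.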